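Three Nucleoside Analogues and an Untested Sulfur-Linked Iodophenyl Variant

The compounds below may be only part of what the source reports. "The series", "measured", "known", "first", "only" and "open" are said of these compounds alone.

The series concerns inhibition of an assay on isolated protein for binding affinity to Equilibrative nucleoside transporter 1 (Homo sapiens); a higher number here means a weaker inhibitor, a lower number a stronger inhibitor. Compound 1 `Nc1ncnc2c1ncn2[C@@H]1O[C@H](COCCOCCNc2ncnc3c2ncn3[C@@H]2O[C@H](CO)[C@@H](O)[C@H]2O)[C@@H](O)[C@H]1O`, a dimer of two adenosine-like units joined through a glycol chain, gives 912000 nM in this assay. Compound 2 `OC[C@H]1O[C@@H](n2cnc3c(OCc4ccccc4)ncnc32)[C@H](O)[C@@H]1O` gives 2090 nM, the lowest number of the three. Compound 3 `Nc1nc(SCCc2ccccc2)c2ncn([C@@H]3O[C@H](CO)[C@@H](O)[C@H]3O)c2n1` gives 16200 nM; the gap from compound 2 to compound 3 lies beyond the usual scatter, and the gap from compound 2 to compound 1 lies far beyond it. Compound 2 thus stands as the strongest inhibitor among the measured compounds.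

Compound 4 `OC[C@H]1O[C@@H](n2cnc3c(CSc4ccccc4I)ncnc32)[C@H](O)[C@@H]1O` has not been measured. It differs from compound 2 in one place: a group of 9 heavy atoms (7 carbon, 1 sulfur, 1 iodine; one six-membered aromatic ring of carbon only) in place of a group of 8 heavy atoms (7 carbon, 1 oxygen; one six-membered aromatic ring of carbon only), on an aromatic carbon. The shared core and the sugar are unchanged; only the group on the six-membered aromatic ring with two nitrogens is exchanged.

Going by the values given here, no measured pair shows this kind of exchange, so the size of the step is uncertain. Compound 3 carries a sulfur-linked aromatic group on the core and gives 16200 nM, but its attachment point differs, so it offers only a loose guide. The step from compound 2 to compound 4 is expected to be small, with no clear direction beyond the scatter, a 1.4-fold lower number from compound 2 to compound 4 (0.14 log units; within the scatter). Compound 4 is accordingly estimated at 1500 nM in this assay, within a range from 300 nM to 8000 nM.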

Compound 4, half-maximal inhibitory concentration: 282 nM
Estimate against measurement, compound 4: 5.3-fold (0.73 log units) above; measured number outside the range, below it.
By their numbers in this assay, from the lowest: compound 4; then compound 2; then compound 3; then compound 1.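

On this aromatic carbon of the six-membered aromatic ring with 2 nitrogen, replacing benzyloxy with the group of 9 heavy atoms (7 carbon, 1 sulfur, 1 iodine) gives a 7.4-fold lower number from compound 2 to compound 4 (0.87 log units; beyond the scatter) in this assay. Going by these compounds alone, this is the first comparison between compounds that differ in one place, and it shows that the read-out responds to the group on this carbon and that benzyloxy is not the best of the groups seen there. Nothing measured here bears on what lies behind the step.

The exchange alters the link to the core and brings in the iodine in a single step, so the compounds shown do not separate what the sulfur-containing link contributes from what the iodine contributes. On these data alone, whether the same group without iodine, one carrying bromine or a methoxy group in place of the iodine, or a longer chain between this carbon and the benzene ring would give a lower or a higher number remains open.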